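The compounds below may be only part of what the source reports. "The series", "measured", "known", "first", "only" and "open" are said of these compounds alone.

In an assay on CHO cells for displacement of a labelled ligand from adenosine receptor A3 (Homo sapiens) (a higher number here means a weaker inhibitor, a lower number a stronger inhibitor), compound 1 `CCn1cnc2ncnc(N)c21` gives > 100000 nM, which is a limit rather than a number. Compound 2 `Nc1ncnc2ncn(CCCO)c12` gives > 100000 nM, again a limit. The step that the two limits leave unreadable from compound 1 to compound 2 therefore cannot be sized, because of the limit of > 100000 nM in this assay, at which 2 of the 3 values shown sit. Going by the values given here, compound 3 `Nc1ncnc2c1nc(Br)n2CCCO` gives 3200 nM, the only number among the three results. Compounds 1 and 2 give only limits, so compound 3 cannot be placed against them. Compound 4 `Nc1ncnc2c1nc(Br)n2CC(O)CO` differs from compound 3 by hydroxy in place of hydrogen on a saturated chain carbon bound to two saturated chain carbons. Among the compounds with values here, the one measured change of a related kind, a step that the two limits leave unreadable from compound 1 to compound 2, offers no readable size, so nothing here points to a step beyond the scatter in either direction. Compound 4 is therefore estimated at 3200 nM, with a range from 800 nM to 15000 nM. The expected step is no change at the digits printed from compound 3 to compound 4 (within the scatter).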

Compound 4, inhibition constant: >= 100000 nM
Compound 4: a limit, no number; the forecaster's own chance of this, stated with the estimate: 10%; at least 31-fold (1.49 log units) between middle value and limit.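

In this assay, hydroxy in place of hydrogen on a saturated chain carbon bound to two saturated chain carbons gives an at least 31-fold higher number from compound 3 to compound 4 (1.49 log units; beyond the scatter). Going by these compounds alone, this is the first step with a readable size, and it shows that going from 3-hydroxypropyl to 2,3-dihydroxypropyl weakens this inhibitor. The full size of the loss stays unknown because compound 4 gives a limit, not a number: the limit of >= 100000 nM in this assay, at which 1 of the 4 values shown sits.

Going by these compounds, whether a methyl or an amine on this same carbon would weaken binding as well remains open. So does the effect of a longer chain ending in hydroxy.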